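Trimming the Dihydroxyethyl Chain of Compound 1

The source may hold more compounds than are shown below. What is called first, only, known or untested is meant among the compounds shown, and "the series" means these compounds.

Compound 1 `Nc1nc(O)c2c(n1)n(C1OC(CO)[C@@H](O)[C@H]1O)c(=O)n2CC(O)CO` gives the highest number of the three measured here: in a functional assay on the whole organism (B cells) with Mus musculus as the target (a lower number here means a smaller maximal response, a higher number a larger maximal response), compound 1 reaches 136%. Compound 2 `C=CCn1c(=O)n(C2CCC(CO)C2)c2nc(N)nc(O)c21` gives 26% in this assay, and compound 3 `Cn1c(=O)n2c3c1c(=O)nc(N)n3CC1OC2[C@H](O)[C@@H]1O` gives 9%, both lying beyond the scatter below compound 1. Compound 4 `CCn1c(=O)n(C2OC(CO)[C@@H](O)[C@H]2O)c2nc(N)nc(O)c21` differs from compound 1 in one place: methyl in place of 1,2-dihydroxyethyl on a saturated chain carbon bound to an aromatic nitrogen. Within the data shown here, no measured pair shows this change by itself, and compounds 2 and 3 differ from compound 1 in several places at once, so the size of the step can only be guessed. The author expects the step of a number 56 percentage points lower from compound 1 to compound 4 (beyond the scatter) to run downward by a moderate amount. Compound 4 is therefore estimated at 80%, with a range from 25% to 135%.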

Compound 4, largest response reached (reported as maximal response), in percent of the reference or control that the assay uses: 82%
Compound 4: the middle estimate sits 2 percentage points below what was measured; the measured number falls inside the stated range.
By their numbers in this assay, from the lowest: compound 3; then compound 2; then compound 4; then compound 1.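

In this assay, among these compounds, the first comparison that changes this place alone gives a number 54 percentage points lower from compound 1 to compound 4 (beyond the scatter) when methyl replaces 1,2-dihydroxyethyl on a saturated chain carbon bound to an aromatic nitrogen. The 2,3-dihydroxypropyl chain thus matters for the maximal response, yet its replacement by ethyl does not abolish that response: compound 4 still gives 82% here. Nothing measured here gives a reason for this step. The compounds shown leave open whether the hydroxyl groups or the chain length carries the step. A propyl chain or a 2-methoxyethyl chain at this place would separate the two.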